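The source may report more compounds than this note shows. Statements on the series, on what has been measured and on what is new or still open speak of the compounds shown alone.

Of the compounds shown here, three have so far been measured in a functional assay on MCF7 cells (Homo sapiens) for cytotoxicity, read by MTT assay, with a stated time of 24 h; on this read-out lower numbers stand for stronger inhibition and higher numbers for weaker inhibition. Compound 3 `O=c1nc2ccccn2cc1Cc1ccc(F)cc1` gives 200000 nM there. Compound 2 `O=c1nc2ccc(Cl)cn2cc1Cc1ccc(F)cc1` differs from compound 3 by chloro in place of hydrogen on an aromatic carbon. In this assay compound 2 gives 10400 nM. That single change made a 19-fold lower number from compound 3 to compound 2 (1.28 log units; beyond the scatter). Compound 1 `CC1(C)OC2O[C@@H](Cc3cn4ccccc4nc3=O)C(OCc3ccccc3)C2O1` carries a different core; how its core differs from that of compound 3 is not broken down here. In this assay compound 1 reaches only a limit, > 1000000 nM. That limit is the one described by the limit of > 1000000 nM in this assay, at which 1 of the 3 values shown sits. Compound 4 `CC1(C)OC2O[C@@H](Cc3cn4cc(Cl)ccc4nc3=O)C(OCc3ccccc3)C2O1` has not yet been measured; it differs from compound 1 by chloro in place of hydrogen on an aromatic carbon, the same change as from compound 3 to compound 2. Because compound 1 gives only a limit > 1000000 nM, the starting point for compound 4 is not a number, and any expectation for compound 4 rests on the earlier step alone. From a 19-fold lower number from compound 3 to compound 2 (1.28 log units; beyond the scatter), a step of an at least 3.3-fold lower number from compound 1 to compound 4 (0.52 log units; beyond the scatter) is expected. Compound 4 is estimated at 300000 nM, between 50000 nM and 1000000 nM.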

Compound 4, half-maximal inhibitory concentration: > 1000000 nM
Compound 4 ended at the assay's limit (the forecaster's own chance of this, stated with the estimate: 45%); middle value at least 3.3-fold (0.52 log units) away from the limit.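

Compound 1 and compound 4 both stand at a limit in this assay, so the step between them cannot be read, and no new comparison follows: the limit of > 1000000 nM in this assay, at which 2 of the 4 values shown sit. The compounds shown leave open what chloro in place of hydrogen on an aromatic carbon does on the core of compound 1, since neither compound gives a number there.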